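A few compounds are considered here, and "the series" means these few. Any claim that something is new, unique, unknown or untested is made for them only; others in the source may bear on it.

Compound 1 `CCC(=O)O[C@@H]1CO[C@H]2[C@@H]1OC[C@@H]2OC(=O)c1ccccc1OC(C)=O` is one of three closely related esters built on a shared core. In an ADME assay on a cell-free system (plasma, Homo sapiens) for metabolic stability, with Plasma (Rattus norvegicus) as the target, read by HPLC, at pH 7.4 (a lower number here means that the compound disappears faster, a higher number that the compound lasts longer), compound 1 gives 0.0608 h. Compound 2 `CC(=O)Oc1ccccc1C(=O)O[C@H]1CO[C@H]2[C@@H]1OC[C@H]2OC(=O)c1ccncc1` gives 0.0617 h, and compound 3 `CC(=O)Oc1ccccc1C(=O)O[C@H]1CO[C@H]2[C@@H]1OC[C@H]2OC(=O)CCO[N+](=O)[O-]` gives 0.065 h, so all three numbers sit within the scatter of one another, and compound 1 stands among them rather than apart from them.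

Compound 4 `CC(=O)Oc1ccccc1C(=O)O[C@H]1CO[C@H]2[C@@H]1OC[C@H]2OC(=O)c1ccc(CO[N+](=O)[O-])cc1` is not yet measured. It differs from compound 1 in one place: 4-((nitrooxy)methyl)phenyl in place of ethyl on a carbonyl carbon.

Among the measured compounds shown here, two measured steps bear on this change. Putting an aromatic ring on the same carbonyl carbon gave a 1.0-fold higher number from compound 1 to compound 2 (0.01 log units; within the scatter), and bringing in a nitrooxy group gave a 1.1-fold higher number from compound 1 to compound 3 (0.03 log units; within the scatter). Neither moved the half-life beyond the scatter, and the step of a 1.1-fold higher number from compound 2 to compound 3 (0.02 log units; within the scatter) between the two variants was likewise small. Compound 4 combines both kinds of change, so no step beyond the scatter is expected in this assay.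

The expected step is therefore a 1.0-fold higher number from compound 1 to compound 4 (0.01 log units; within the scatter). Compound 4 is estimated to give 0.062 h, with a range from 0.03 h to 0.13 h.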

Compound 4, half-life: 0.1 h
For compound 4 the middle estimate is 1.6-fold (0.21 log units) below the measured one; the measured number falls inside the stated range.
By their numbers in this assay, from the lowest: compounds 1, 2, 3 and 4 (each within the scatter of the next).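

In this assay, the carbonyl carbon also accepts 4-((nitrooxy)methyl)phenyl, with 11 heavy atoms against 2 for ethyl, and the step is a 1.6-fold higher number from compound 1 to compound 4 (0.22 log units; within the scatter). The comparisons with the other two groups agree, with a 1.5-fold higher number from compound 3 to compound 4 (0.19 log units; within the scatter) and a 1.6-fold higher number from compound 2 to compound 4 (0.21 log units; within the scatter), so an aromatic ring and a nitrooxy group together in one substituent stay within the scatter, as the pyridin-4-yl and 2-(nitrooxy)ethyl groups did. Nothing measured here offers an explanation for these numbers.

On these data alone, it remains open whether any group on this carbonyl carbon, such as a chain ending in an amine or a carboxylic acid, would give a step beyond the scatter. As far as these compounds go, the other ester group is the same in all four compounds, so the effect of replacing it, for instance with an amide, also remains open.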